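The source may report more compounds than this note shows. Statements on the series, on what has been measured and on what is new or still open speak of the compounds shown alone.

Compound 1 `O=C1CC(c2c(-c3ccc[nH]3)[nH]c3ccccc23)C(=O)N1` gives 67000 nM in a functional assay on OE21 cells (Homo sapiens) for cytotoxicity, read by MTT assay, with a stated time of 72 h; a lower number here means a stronger inhibitor, a higher number a weaker inhibitor. Compound 2 `Cc1ccc2[nH]c(-n3cccn3)c(C3=C(Br)C(=O)NC3=O)c2c1` gives 28000 nM. Compound 3 `O=C1NC(=O)C(c2c(-n3cccn3)[nH]c3ccccc23)=C1Br` gives 27000 nM.

Compound 2 and compound 3 differ in one place, (methyl in place of hydrogen on an aromatic carbon), and that step brought a 1.0-fold higher number from compound 3 to compound 2 (0.02 log units; within the scatter). Compound 1 carries a different core; how its core differs from that of compound 3 is not broken down here, and compound 1 simply gives a higher number than compound 2 and compound 3. Compound 4 `Cc1ccc2[nH]c(-c3ccc[nH]3)c(C3CC(=O)NC3=O)c2c1` has not yet been measured. It differs from compound 1 by methyl in place of hydrogen on an aromatic carbon, the same change as that from compound 3 to compound 2, made on the core of compound 1. Because the measured step of a 1.0-fold higher number from compound 3 to compound 2 (0.02 log units; within the scatter) lay within the scatter, the step of a 1.0-fold lower number from compound 1 to compound 4 (0.01 log units; within the scatter) is expected to be of the same small size. Compound 4 is therefore estimated at 65000 nM, between 30000 nM and 140000 nM.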

Compound 4, half-maximal inhibitory concentration: > 100000 nM
Compound 4: only a limit was reported (the forecaster's own chance of this, stated with the estimate: 15%); at least 1.5-fold (0.18 log units) between middle value and limit.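

In this assay compound 4 gives > 100000 nM, which is a limit of the assay and not a number. On the core of compound 1, methyl in place of hydrogen on an aromatic carbon brought an at least 1.4-fold higher number from compound 1 to compound 4 (0.17 log units; that floor lies within the scatter). The change can thus be set side by side on the two cores, but the result does not show whether it carries over from one core to the other at the same size: the same change on two cores in this assay, a 1.0-fold higher number (0.02 log units; within the scatter) from compound 3 to compound 2 and an at least 1.4-fold higher number (0.17 log units; that floor lies within the scatter) from compound 1 to compound 4; the limit leaves it open whether they differ

On these data alone, the actual value of compound 4 remains open, and with it the full size of this step. Also open, as far as these compounds go, is what a longer chain, an amine or a carboxylic acid on the same aromatic carbon would do on either core.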